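Fluoro for isobutylcarbamoyl on the indole ring of compound 1

The source may hold more compounds than are shown below. What is called first, only, known or untested is meant among the compounds shown, and "the series" means these compounds.

Compound 1 `CCC1C(=O)N(C)c2cnc(-n3ccc4cc(C(=O)NCC(C)C)ccc43)nc2N1c1ccn(C)n1` is one of two measured members of this series. In an assay for inhibition of serine/threonine-protein kinase PLK2 (Homo sapiens), read by FRET and Z'-LYTE, with a stated time of 1 h (on this read-out lower numbers stand for stronger inhibition and higher numbers for weaker inhibition), compound 1 gives 159 nM, the higher of the two numbers recorded. Among the measured compounds shown here, compound 2 `CC[C@@H]1C(=O)N(C)c2cnc(-n3ccc4cc(C(=O)NCC(C)C)ccc43)nc2N1C1CCCC1` gives 18.6 nM in this assay, a lower number beyond the usual scatter, though the two compounds differ in more than one place, so no single step is counted between them.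

Compound 3 `CCC1C(=O)N(C)c2cnc(-n3ccc4cc(F)ccc43)nc2N1c1ccn(C)n1` is not yet measured in this assay. It differs from compound 1 as follows: fluoro in place of isobutylcarbamoyl on an aromatic carbon. For the measured compounds named here, the isobutylcarbamoyl group is shared by both measured compounds; the series so far holds no measurement of a compound without it, so its contribution is untested.

The step from compound 1 to compound 3 is expected to be a rise, beyond the scatter, of about a 4.4-fold higher number from compound 1 to compound 3 (0.64 log units; beyond the scatter). For compound 3 in this assay the estimate is 700 nM, with a range from 200 nM to 2500 nM.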

Compound 3, half-maximal inhibitory concentration: 1500 nM
Beside the measured number, compound 3's estimate is 2.1-fold (0.33 log units) below it, and the stated range covers the measured number.
By their numbers in this assay, from the lowest: compound 2; then compound 1; then compound 3.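

The isobutylcarbamoyl group, shared by both earlier compounds, now has a measured contribution on this core: in this assay replacing it with fluoro on the aromatic carbon gives a 9.4-fold higher number from compound 1 to compound 3 (0.97 log units; beyond the scatter) and the step lies beyond the scatter. This position therefore does affect the read-out, and fluoro does not stand in for the group there. The change removes the whole group at once, so the step cannot be assigned to the carbonyl, the amide hydrogen or the isobutyl chain, and nothing measured here bears on its cause.

Open, going by these compounds, is whether a shorter N-methyl amide, a carboxylic acid or a nitrile at this position would hold the number nearer that of compound 1. Also open, on these data alone, is whether the same change carries a step of similar size with the cyclopentyl group of compound 2.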